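The source may report more compounds than this note shows. Statements on the series, on what has been measured and on what is new or still open speak of the compounds shown alone.

Compound 1 `COc1ccc(SCc2ccc(/C=C/C(=O)Nc3ccccc3N)cc2)cc1OC` gives 46% in a functional assay on A-375 cells (Homo sapiens) for inhibition, read by CCK-8 assay, with a stated time of 72 h, tested at 2 uM; on this read-out higher numbers stand for more inhibition of growth at the one concentration tested and lower numbers for less inhibition of growth. Compound 2 `Nc1ccccc1NC(=O)/C=C/c1ccc(CSc2ccc(C(F)(F)F)cn2)cc1` gives 10.3%. Compound 3 `Nc1ccccc1NC(=O)/C=C/c1ccc(CSc2ccc(F)cc2)cc1` is not yet measured.

Compound 1 stands highest of the two numbers shown. Compound 3 differs from it in one place: 4-fluorophenyl in place of 3,4-dimethoxyphenyl on a sulfur. Going by the values given here, one measured step bears on this change at the same sulfur: a number 35.7 percentage points lower from compound 1 to compound 2 (beyond the scatter), a large drop on swapping the group there. On these data alone, a change on this sulfur is therefore expected to lower this assay, though the fluorophenyl case is untested. The estimate is a number 18 percentage points lower from compound 1 to compound 3 (beyond the scatter). Compound 3 is expected to reach about 28%, within 8% to 48%.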

Compound 3, percent growth inhibition at one concentration: 28.8%
Compound 3: the middle estimate sits 0.8 percentage points below what was measured; measured number inside the range.
By their numbers in this assay, from the lowest: compound 2; then compound 3; then compound 1.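

In this assay, the sulfur position now carries three groups at three separate levels: 4-fluorophenyl in place of 3,4-dimethoxyphenyl gives a number 17.2 percentage points lower from compound 1 to compound 3 (beyond the scatter), while 4-fluorophenyl in place of 5-(trifluoromethyl)pyridin-2-yl gives a number 18.5 percentage points higher from compound 2 to compound 3 (beyond the scatter). The loss seen earlier at this sulfur is therefore graded rather than all-or-nothing, with 4-fluorophenyl retaining an intermediate level of growth inhibition. No supporting measurements are available to explain these differences. Which part of 3,4-dimethoxyphenyl matters remains open, since one methoxy group alone is not among these compounds. On these data alone, how an amine or a carboxylic acid on the aromatic ring would read is also open.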